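Compound 3: cyclopentyl in place of methyl

This account rests on a few compounds, and the source may have more. Where it says the series, first, only, none or still open, it means among the compounds named here.

Compound 1 `CCCN(Cc1ccc(OCCN2C(=O)CCC2=O)c(C)c1)[C@@H](CC(=O)O)c1ccc(Cl)cc1`: 97%
Compound 2 `CCN(Cc1ccc(OCCN2C(=O)CCC2=O)c(C)c1)C(CC(=O)O)c1ccc(Cl)cc1`: 100%

Both compounds were tested in an ADME assay on liver (Homo sapiens) for metabolic stability, read by LC-MS, using microsomes and NADPH; on this read-out higher numbers stand for a more stable compound and lower numbers for a less stable compound. Compound 2 gives 100% and compound 1 gives 97%, two values that lie within the usual scatter of each other. Nearly all of each compound therefore remains, and compound 2 stands at the top of the scale.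

Compound 3 `Cc1cc(CN(CC2CCCC2)C(CC(=O)O)c2ccc(Cl)cc2)ccc1OCCN1C(=O)CCC1=O` has not yet been measured in this assay. It departs from compound 2 in one place: cyclopentyl in place of methyl on a saturated chain carbon bound to an amine nitrogen. This puts cyclopentyl in place of methyl on a saturated chain carbon bound to an amine nitrogen, so the same difference reads ethyl to cyclopentylmethyl.

Within the data shown here, no measured pair shows what this change does, so the expectation is uncertain. The number for compound 3 can hardly rise, as compound 2 already gives 100%. A modest downward move is expected, probably somewhat beyond the scatter. The estimated step is a number 15 percentage points lower from compound 2 to compound 3 (beyond the scatter). For compound 3 the estimated value is 85%, with an expected range of 65% to 98%.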

Compound 3, percent of the compound remaining: 65%
Estimate against measurement, compound 3: 20 percentage points above; the measured number falls inside the stated range.
By their numbers in this assay, from the lowest: compound 3; then compounds 1 and 2 (each within the scatter of the next).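

In this assay, among these compounds, the change of methyl to cyclopentyl on a saturated chain carbon bound to an amine nitrogen gives a number 35 percentage points lower from compound 2 to compound 3 (beyond the scatter) and is the first single-place step that can be read. It shows that this position is not indifferent to the group it carries, which the two earlier compounds, both close to the top of the scale, could not reveal. Nothing available explains the fall, so it stands as an observation for this one pair.

The compounds shown leave open whether the ring itself matters here or whether an open chain would do the same, a question that a straight pentyl chain or a smaller cyclopropyl ring in place of cyclopentyl on the same carbon would begin to settle. Also open, from the compounds shown here alone, is whether a ring carrying an oxygen atom, such as tetrahydropyranyl, would bring the number back towards that of compound 2 at this position.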